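This account rests on a few compounds, and the source may have more. Where it says the series, first, only, none or still open, it means among the compounds named here.

In an ADME assay on the whole organism with Oryza sativa as the target, tested at 1 uM (a higher number here means a weaker effect of the compound at the concentration tested, a lower number a stronger effect), compound 2 `CC(C)c1ccccc1NC(=O)N[C@H](C)c1ccccc1` gives 101%. Its two measured neighbours are compound 1 `Cc1ccccc1NC(=O)N[C@H](C)c1ccccc1`, which in this assay gives 100%, and compound 3 `CC(C)c1ccccc1NC(=O)N[C@@H](C)c1ccccc1`, which gives 96%. Compound 2 holds the top of these three numbers, yet both steps, a number 1 percentage points higher from compound 1 to compound 2 (within the scatter) and a number 5 percentage points lower from compound 2 to compound 3 (within the scatter), are within the scatter, so the three compounds cannot be told apart in this assay. The second of those steps rests on (the fact that compounds 2 and 3 differ only in the configuration as drawn).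

Compound 4 `C[C@@H](NC(=O)Nc1ccccc1C(F)(F)F)c1ccccc1` has not been measured. It differs from compound 2 in one place: trifluoromethyl in place of isopropyl on an aromatic carbon. For the measured compounds named here, no measured step involves a trifluoromethyl. The one that bears most closely on the change is a number 1 percentage points higher from compound 1 to compound 2 (within the scatter), an exchange of one alkyl group for another on an aromatic carbon of the same ring, which left the number essentially where it was. Going by the values given here, with all three measured numbers close to one another and no step yet beyond the scatter, the expected step, a number 2 percentage points lower from compound 2 to compound 4 (within the scatter), is also one within the scatter. Compound 4 is therefore estimated to give 99% in this assay, with a range from 90% to 108%.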

Compound 4, a percentage reported as activity, at one concentration (the size of the read-out at that concentration, not a potency): 95%
Compound 4: middle estimate off by 4 percentage points, on the high side; the measured number falls inside the stated range.
By their numbers in this assay, from the lowest: compounds 4, 3, 1 and 2 (each within the scatter of the next).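

Until now only alkyl groups had stood on this aromatic carbon, ortho to a large group, and the exchange of isopropyl for trifluoromethyl, which puts fluorine at this place for the first time among these compounds, brings a number 6 percentage points lower from compound 2 to compound 4 (within the scatter) in this assay for this change. The exchange of methyl for trifluoromethyl at the same place brings a number 5 percentage points lower from compound 1 to compound 4 (within the scatter) in the same read-out, so in these compounds the number stays within the scatter whether an alkyl group or trifluoromethyl sits there, and the four compounds still cannot be told apart. Nothing known about these compounds speaks to why trifluoromethyl behaves in this way here.

With every step so far within the scatter, the compounds shown leave open whether any group on this aromatic carbon can move the number in this assay at all. As far as these compounds go, how a nitrile, an amine, a carboxylic acid or a longer chain at this same place would read remains unknown, and so does whether any of them would produce a step beyond the scatter.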